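This account rests on a few compounds, and the source may have more. Where it says the series, first, only, none or still open, it means among the compounds named here.

Compound 1 `CC(C)(C)Cc1c(-c2ccccc2)sc(N)c1C(=O)c1cccc(Cl)c1`: 5%
Compound 2 `CC(C)(C)Cc1c(-c2ccccc2)sc(N)c1C(=O)c1ccccc1Cl`: 1%
Compound 3 `CC(C)(C)Cc1c(-c2ccccc2)sc(N)c1C(=O)c1ccc(Cl)c(Cl)c1`: 6%

Three compounds sharing one core, and differing only in the chlorine-bearing phenyl on the carbonyl carbon, have been measured in an assay on CHO cells for displacement of a labelled ligand from adenosine receptor A3 (Homo sapiens), read by scintillation counting, tested at 10 uM; on this read-out higher numbers stand for more inhibition at the one concentration tested (going by the name of the read-out) and lower numbers for less inhibition. Compound 1 gives 5%, compound 2 gives 1%, and compound 3 gives 6%. Compound 3 is set apart from neither of the others: a number 1 percentage points higher from compound 1 to compound 3 (within the scatter) and a number 5 percentage points higher from compound 2 to compound 3 (within the scatter) both lie within the scatter, as does a number 4 percentage points lower from compound 1 to compound 2 (within the scatter), so the three numbers sit together near the floor of the read-out in this assay.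

Compound 4 `CC(C)(C)Cc1c(-c2ccccc2)sc(N)c1C(=O)c1ccc(Cl)cc1Cl` is the next member of the set. Its difference from compound 3 is 2,4-dichlorophenyl in place of 3,4-dichlorophenyl on a carbonyl carbon. The measured steps that bear on this change are the two that likewise rearranged chlorine on the phenyl attached to the carbonyl carbon, a number 4 percentage points lower from compound 1 to compound 2 (within the scatter) and a number 5 percentage points higher from compound 2 to compound 3 (within the scatter), and neither of them left the scatter. On that basis no step beyond the scatter is expected for compound 4 in this assay, in either direction, and the expected step is a number 1 percentage points lower from compound 3 to compound 4 (within the scatter). Compound 4 is therefore estimated at 5%, with a range of 0% to 15%.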

Compound 4, a percentage reported as inhibition, at one concentration (the size of the read-out at that concentration, not a potency): 1%
The estimate for compound 4 lay 4 percentage points above the measured number, within the range that was stated.
By their numbers in this assay, from the lowest: compounds 2, 4, 1 and 3 (each within the scatter of the next).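

The position on the carbonyl carbon now has a fourth chlorine pattern, and 2,4-dichlorophenyl does not separate from the earlier groups in this assay: the exchange for 3,4-dichlorophenyl gives a number 5 percentage points lower from compound 3 to compound 4 (within the scatter), and the exchange for 3-chlorophenyl gives a number 4 percentage points lower from compound 1 to compound 4 (within the scatter). Going by these compounds alone, compound 4 also allows the first look at one added chlorine on the 2-chlorophenyl group, which gives no change at the digits printed from compound 2 to compound 4 (within the scatter). With that step, the same addition can be compared on two different phenyl groups, and the two results agree: the same change on two cores in this assay, a number 1 percentage points higher (within the scatter) from compound 1 to compound 3 and no change at the digits printed (within the scatter) from compound 2 to compound 4, 1 percentage points apart, within the scatter of two such steps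

All four compounds therefore remain together near the floor of the read-out, and none of these chlorine patterns on the phenyl stands apart from the others. On these data alone, what remains open is whether a different group on this phenyl, such as an amine, a methoxy group or a carboxylic acid, would raise the number beyond the scatter, and a reading at one concentration this close to the floor gives no measure of potency for any of the four compounds.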